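A few compounds are considered here, and "the series" means these few. Any claim that something is new, unique, unknown or untested is made for them only; others in the source may bear on it.

Compound 1, with the structure `COc1cc2nc(-c3ccc(C(F)(F)F)cc3)cc(OCCCN3CCCCC3)c2cc1OC`, is tested in a functional assay on A498 cells (Homo sapiens) for inhibition, read by sulforhodamine B assay, with a stated time of 48 h (on this read-out higher numbers stand for weaker inhibition of growth and lower numbers for stronger inhibition of growth), where compound 1 gives 1850 nM. Among the two compounds measured so far this is the higher number, though its only neighbour lies within the usual scatter: compound 2, with the structure `COc1cc2nc(-c3ccc(Cl)cc3)cc(OCCCN3CCCCC3)c2cc1OC`, gives 1400 nM, and the step of a 1.3-fold lower number from compound 1 to compound 2 (0.12 log units; within the scatter) is too small to count as a real difference.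

The next compound, compound 3, has the structure `COc1cc2nc(-c3ccc(C(F)(F)F)cc3)cc(OCCCN3CCCC3)c2cc1OC`. It keeps everything in compound 1 except one place: pyrrolidin-1-yl in place of piperidin-1-yl on a saturated chain carbon, three bonds along the chain from an oxygen on an aromatic ring. Among the compounds with values here, no measured step bears on this change. Within the data shown here, the one step available, from compound 1 to compound 2, alters a group on the aromatic ring at the other end of the molecule and leaves the saturated chain untouched, so it says nothing about shrinking the ring at the chain's end. With no evidence either way, the expectation is a step from compound 1 to compound 3 that stays inside the scatter, with a 1.0-fold lower number from compound 1 to compound 3 (0.01 log units; within the scatter) as the expected size. For compound 3 the estimate in this assay is therefore 1800 nM, expected to fall between 900 nM and 3600 nM.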

Compound 3, concentration for 50% growth inhibition: 1580 nM
Estimate against measurement, compound 3: 1.1-fold (0.06 log units) above; low and high end bracket the measured number.
By their numbers in this assay, from the lowest: compounds 2, 3 and 1 (each within the scatter of the next).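

Within the data shown here, this is the first change at the far end of the saturated chain, and in this assay going from the six-membered piperidin-1-yl ring to the five-membered pyrrolidin-1-yl ring gives a 1.2-fold lower number from compound 1 to compound 3 (0.07 log units; within the scatter). At this position, then, the two ring sizes cannot be told apart in growth inhibition, just as the change on the aromatic ring at the other end of the molecule gives a 1.3-fold lower number from compound 1 to compound 2 (0.12 log units; within the scatter), also too small to read as a real difference. Nothing available here offers any explanation for the two rings reading alike.

What the compounds shown leave open is whether this chain end responds to anything larger than a change of one ring member, for instance a morpholin-4-yl ring with its added oxygen, or an open diethylamino group in place of the ring. Also open, from the compounds shown here alone, is whether pairing pyrrolidin-1-yl with the chloro group of compound 2 would stay as close to these numbers, or whether a longer chain would move the value beyond the usual scatter.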